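The source may report more compounds than this note shows. Statements on the series, on what has been measured and on what is new or still open speak of the compounds shown alone.

Compound 2 `CN1CCN(C2CCN(c3ccc(Nc4ncc5c(F)c(C6CC6)n(-c6cccc(C(C)(C)O)n6)c5n4)cc3)CC2)CC1` gives 211 nM in a functional assay on NCI-H1299 cells (Homo sapiens) for inhibition, read by luminescence and CellTiter-Glo, with a stated time of 3 days; a lower number here means a stronger inhibitor, a higher number a weaker inhibitor. Compound 1 `CN1CCN(C2CCN(c3ccc(Nc4ncc5c(F)c(C6CC6)n(-c6cccc(C(C)(C)O)n6)c5n4)cc3F)CC2)CC1` differs from it by fluoro in place of hydrogen on an aromatic carbon, and that change made a 3.0-fold higher number from compound 2 to compound 1 (0.47 log units; beyond the scatter); compound 1 gives 623 nM. Compound 3 `CCCc1cc2cnc(Nc3ccc(N4CCN(C)CC4)cc3)nc2n1-c1cccc(C(C)(C)O)n1` rests on a different core; how its core differs from that of compound 2 is not broken down here. In this assay compound 3 gives 126 nM. Compound 4 `CCCc1c(F)c2cnc(Nc3ccc(N4CCN(C)CC4)cc3)nc2n1-c1cccc(C(C)(C)O)n1` carries fluoro in place of hydrogen on an aromatic carbon. This is the same kind of change as that made from compound 2 to compound 1, but the place differs: there the fluoro sat on a six-membered aromatic ring of carbon only, ortho to a large group, meta to a large group; here it sits on a five-membered aromatic ring with 1 nitrogen, part of a fused or bridged system of two rings, next to the ring atom that bears a propyl group. Resting on a 3.0-fold higher number from compound 2 to compound 1 (0.47 log units; beyond the scatter), compound 4 is expected to show a 2.4-fold higher number from compound 3 to compound 4 (0.38 log units; beyond the scatter), with the different surroundings weakening the parallel. Compound 4 is estimated at 300 nM, between 140 nM and 800 nM.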

Compound 4, half-maximal inhibitory concentration: 1720 nM
Estimate against measurement, compound 4: 5.7-fold (0.76 log units) below; the measured number lies above the stated range.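

In this assay, fluoro in place of hydrogen on an aromatic carbon of the five-membered aromatic ring gave a 14-fold higher number from compound 3 to compound 4 (1.14 log units; beyond the scatter). Set beside the earlier step, the direction carried over from one core to the other, but the size did not: the same change on two cores in this assay, a 3.0-fold higher number (0.47 log units; beyond the scatter) from compound 2 to compound 1 and a 14-fold higher number (1.14 log units; beyond the scatter) from compound 3 to compound 4, 4.6-fold (0.66 log units) apart, beyond the scatter of two such steps With only one pair on each core, and the fluoro in a different place in each pair, these compounds cannot separate the effect of the core from that of the place, so the size of the step cannot be carried from one core to another.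

From the compounds shown here alone, it remains open whether chloro or a methyl group on the same aromatic carbon would give a step of similar size. Also open, going by these compounds, is how the step would change with a longer chain in place of the propyl group.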